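The source may report more compounds than this note shows. Statements on the series, on what has been measured and on what is new or still open speak of the compounds shown alone.

Compound 1 `NC1(CCn2ncc(=O)[nH]c2=O)OC(=O)C(OCc2ccccc2)=C1OCc1ccccc1` and compound 2 `NC1(CCn2cc(F)c(=O)[nH]c2=O)OC(=O)C(OCc2ccccc2)=C1OCc1ccccc1` share one core and differ only in the ring carried on the saturated chain carbon. In a functional assay on MCF7 cells (Homo sapiens) for inhibition, read by MTT assay, with a stated time of 72 h (a lower number here means a stronger inhibitor, a higher number a weaker inhibitor), compound 1 gives only a limit of the assay, > 100000 nM. In this assay compound 2 gives 20900 nM. The step of an at least 4.7-fold lower number from compound 1 to compound 2 (0.67 log units; beyond the scatter) is therefore at least modest, and its true size is open because the limit of > 100000 nM in this assay, at which 1 of the 2 values shown sits, holds the figure for compound 1. Among the numbers shown, compound 2 thus stands as the only measured value, the other entry being a limit.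

Compound 3 `NC1(CCn2ccc(=O)[nH]c2=O)OC(=O)C(OCc2ccccc2)=C1OCc1ccccc1` differs from compound 2 by hydrogen in place of fluoro on an aromatic carbon. Going by the values given here, no measured step bears on this exchange; the single known step concerns a different ring. The estimate for compound 3 is therefore a step of a 1.9-fold higher number from compound 2 to compound 3 (0.28 log units; within the scatter), close to no change or a mild weakening. Compound 3 is expected to give 40000 nM, within 15000 nM to 120000 nM.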

Compound 3, half-maximal inhibitory concentration: > 100000 nM
Compound 3: only a limit was reported; the forecaster's own chance of this, stated with the estimate: 25%; middle value at least 2.5-fold (0.39 log units) away from the limit.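

In this assay, going by these compounds alone, hydrogen in place of fluoro on this aromatic carbon, the only change between the two structures, gives an at least 4.7-fold higher number from compound 2 to compound 3 (0.67 log units; beyond the scatter). The earlier pair changed the ring itself, whereas this pair shows that the single fluoro atom at this position is enough to separate a measured number from a limit, and compound 2 remains the only compound shown with a measured number. The step runs from a number to a limit, so its true size stays open: the limit of > 100000 nM in this assay, at which 2 of the 3 values shown sit.

Compound 1 and compound 3 both stand at limits, and the step between them cannot be read. Within the data shown here, whether chloro, methyl or an amine on the same aromatic carbon would also give a measured number, and how that number would compare with the one for compound 2, remains open.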